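A few compounds are considered here, and "the series" means these few. Any claim that something is new, unique, unknown or untested is made for them only; others in the source may bear on it.

In a functional assay on DU-145 cells (Homo sapiens) for cytotoxicity, read by trypan blue exclusion, with a stated time of 96 h (a lower number here means a stronger inhibitor, a higher number a weaker inhibitor), compound 1 (`COc1ccc(OC)c(/C=C/S(=O)(=O)Cc2ccc(OC)c(N)c2)c1`) gives 750 nM and compound 2 (`COc1ccc(CS(=O)(=O)/C=C/c2c(OC)cc(O)cc2OC)cc1N`) gives 200 nM. Compound 3 (`COC(=O)C(C)(C)Nc1cc(CS(=O)(=O)/C=C/c2c(OC)cc(OC)cc2OC)ccc1OC`) gives 2500 nM, the highest of the three numbers and clearly beyond the usual scatter from both others, so it is the weakest inhibitor of the set.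

Compound 4 (`COc1cc(OC)c(/C=C/S(=O)(=O)Cc2ccc(OC)c(N[C@@H](C)C(=O)O)c2)c(OC)c1`) differs from compound 3 in one place: 1-carboxyethyl stands in place of 1-(methoxycarbonyl)-1-methylethyl on a nitrogen on an aromatic ring (1-carboxyethyl in place of 1-(methoxycarbonyl)-1-methylethyl on a nitrogen on an aromatic ring). The entering group also brings one defined stereocentre.

Among the compounds with values here, no measured compound carries this new group, so the guide is indirect. Compound 1 at 750 nM and compound 2 at 200 nM have nothing attached to that nitrogen and both sit well under compound 3, although they also differ from it elsewhere. A fall beyond the scatter is therefore expected, estimated as a 13-fold lower number from compound 3 to compound 4 (1.10 log units; beyond the scatter). The estimate for compound 4 is 200 nM, with an expected range of 40 nM to 1000 nM.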

Compound 4, half-maximal inhibitory concentration: 25 nM
Estimate against measurement, compound 4: 8.0-fold (0.90 log units) above; the measured number lies below the stated range.
By their numbers in this assay, from the lowest: compound 4; then compound 2; then compound 1; then compound 3.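

In this assay, the group on the nitrogen on an aromatic ring proves able to move the number strongly: 1-carboxyethyl in place of 1-(methoxycarbonyl)-1-methylethyl gives a 100-fold lower number from compound 3 to compound 4 (2.00 log units; beyond the scatter). Compound 3 alone could not show how sensitive this position is, nor that a group on this nitrogen can go with a low number. The change alters several things at once, since the methyl ester gives way to a carboxylic acid, a methyl group is lost and a defined stereocentre enters, and nothing available explains the step.

Which of these differences carries the step stays open; the methyl ester of 1-carboxyethyl, 1-carboxy-1-methylethyl and the opposite stereocentre would separate them. Going by these compounds, whether a longer chain such as 2-carboxyethyl, or an amide in place of the acid, would behave alike is also open.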